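Methoxy to dimethylsulfamoyl on the aromatic carbon of the core

The source may report more compounds than this note shows. Statements on the series, on what has been measured and on what is new or still open speak of the compounds shown alone.

Measured compounds:
compound 1 `CN1CCN(CCCN(C(=O)Nc2ccc(F)c(Cl)c2)C2CCc3cc(C#N)ccc3C2)CC1`, 340 nM in an assay on CHO cells for binding affinity to melanin-concentrating hormone receptor 1 (Homo sapiens); on this read-out higher numbers stand for weaker inhibition and lower numbers for stronger inhibition
compound 2 `COc1ccc2c(c1)CCC(N(CCCN1CCN(C)CC1)C(=O)Nc1ccc(F)c(Cl)c1)C2`, 190 nM
compound 3 `COc1ccc2c(c1)CC(N(CCCN1CCN(C)CC1)C(=O)Nc1ccc(F)c(Cl)c1)CC2`, 92 nM

Compound 3 gives the lowest number of the three in this assay, beyond the scatter from compound 2 and from compound 1. Within the data shown here, the only single-point step measured so far is a 1.8-fold lower number from compound 1 to compound 2 (0.25 log units; within the scatter), methoxy in place of cyano on an aromatic carbon. Compound 4 `CN1CCN(CCCN(C(=O)Nc2ccc(F)c(Cl)c2)C2CCc3ccc(S(=O)(=O)N(C)C)cc3C2)CC1` differs from compound 3 by dimethylsulfamoyl in place of methoxy on an aromatic carbon. Among the measured compounds shown here, no measured step involves a dimethylsulfamoyl group, so nothing measured bears directly on this change; the one measured substituent swap stayed within the scatter. The step from compound 3 to compound 4 is therefore expected to be a 1.6-fold higher number from compound 3 to compound 4 (0.21 log units; within the scatter), with wide uncertainty. Compound 4 is estimated at 150 nM, between 40 nM and 600 nM.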

Compound 4, inhibition constant: 3000 nM
The estimate for compound 4 lay 20-fold (1.30 log units) below the measured number, outside the stated range (above it).
By their numbers in this assay, from the lowest: compound 3; then compounds 2 and 1 (each within the scatter of the next); then compound 4.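

In this assay, among these compounds, dimethylsulfamoyl in place of methoxy gives a 33-fold higher number from compound 3 to compound 4 (1.51 log units; beyond the scatter), so a substituent swap on this aromatic carbon can shift the number far beyond the scatter, which the earlier compounds did not show. The change brings in six heavy atoms for two, with no ring and no net charge on either group. Nothing available accounts for this step.

As far as these compounds go, whether size or the sulfamoyl group itself goes with the weaker number remains open. An ethoxy or methylsulfonyl group on the same carbon would help separate the two.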